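The source may hold more compounds than are shown below. What is called first, only, known or untested is meant among the compounds shown, and "the series" means these compounds.

Measured so far:
- Compound 1 `C[C@H]1CC[C@@H]2[C@@H](OC(=O)[C@]23CC(c2ccccc2Br)=NO3)[C@]2(C)C(=O)C=C[C@@]12O` gives 44000 nM in a functional assay on SW-620 cells (Homo sapiens) for cytotoxicity, read by sulforhodamine B assay, with a stated time of 48 h; a lower number here means a stronger inhibitor, a higher number a weaker inhibitor
- Compound 2 `C[C@H]1CC[C@@H]2[C@@H](OC(=O)[C@]23CC(c2cccc([N+](=O)[O-])c2)=NO3)[C@]2(C)C(=O)C=C[C@@]12O` gives 49000 nM in this assay

Compound 2 stands level with compound 1, and the two values cannot be separated within the scatter. The next structure is compound 3 `Cc1ccccc1C1=NO[C@]2(C1)C(=O)O[C@@H]1[C@H]2CC[C@H](C)[C@]2(O)C=CC(=O)[C@@]12C` and its change from compound 2 is 2-methylphenyl in place of 3-nitrophenyl on a carbon with a double bond to nitrogen with 2-methylphenyl in place of 3-nitrophenyl on a carbon with a double bond to nitrogen, next to the ring nitrogen. The shared core stays the same.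

Within the data shown here, only one measured step bears on this change. That step, a 1.1-fold higher number from compound 1 to compound 2 (0.05 log units; within the scatter), exchanged the group at the same place and stayed within the scatter. Among the measured compounds shown here, two compounds give a thin base, and no compound with 2-methylphenyl has been measured. No shift beyond the scatter is therefore expected in this assay for either direction. The expected step is a 1.1-fold lower number from compound 2 to compound 3 (0.04 log units; within the scatter) by estimate. The estimated value of compound 3 is 45000 nM with an expected range from 22000 nM to 90000 nM for this read-out.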

Compound 3, half-maximal inhibitory concentration: 5000 nM
For compound 3 the middle estimate is 9.0-fold (0.95 log units) above the measured one; measured number outside the range, below it.
By their numbers in this assay, from the lowest: compound 3; then compounds 1 and 2 (each within the scatter of the next).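

In this assay, the group on the carbon with a double bond to nitrogen can move the read-out, which the first two compounds did not show: 2-methylphenyl in place of 3-nitrophenyl gives a 9.8-fold lower number from compound 2 to compound 3 (0.99 log units; beyond the scatter) in this series, whereas the earlier exchange at this place, a 1.1-fold higher number from compound 1 to compound 2 (0.05 log units; within the scatter), stayed within the scatter. The closest comparison is methyl in place of bromo on an aromatic carbon, an 8.8-fold lower number from compound 1 to compound 3 (0.94 log units; beyond the scatter), a change of one group that leaves the names 2-bromophenyl and 2-methylphenyl differing only in that group, so the number at this place depends on what the phenyl ring carries and not just on its being a substituted phenyl. No measurement at hand accounts for this shift.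

Among these compounds, with compound 3 as the only compound below the other two, a single methyl-bearing phenyl carries the whole finding, and it remains open whether an ethyl, a methoxy or an amine on the phenyl ring would hold or extend the lower number. Also open, going by these compounds, is whether 3-methylphenyl or 4-methylphenyl would match 2-methylphenyl, and whether an unsubstituted phenyl would sit with compound 3 or with compound 1 and compound 2.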